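A few compounds are considered here, and "the series" means these few. Any claim that something is new, unique, unknown or untested is made for them only; others in the source may bear on it.

Working notes on the series in a functional assay on HT-29 cells (Homo sapiens) for antiproliferative activity, read by MTT assay, with a stated time of 72 h; on this read-out higher numbers stand for weaker inhibition and lower numbers for stronger inhibition: compound 1 (`CC(C)(O)COc1ccc2c(Oc3ccc(Nc4nccc5[nH]cc(-c6ccc(F)cc6)c(=O)c45)cc3F)ccnc2c1`) gives 3400 nM, compound 2 (`O=c1c(-c2ccc(F)cc2)c[nH]c2ccnc(Nc3ccc(Oc4ccnc5cc(O)ccc45)c(F)c3)c12`) gives 5900 nM, and compound 3 (`CC(O)COc1ccc2c(Oc3ccc(Nc4nccc5[nH]cc(-c6ccc(F)cc6)c(=O)c45)cc3F)ccnc2c1`) gives 3900 nM, which stands within the scatter of both others. Compound 4 (`COCCOc1ccc2c(Oc3ccc(Nc4nccc5[nH]cc(-c6ccc(F)cc6)c(=O)c45)cc3F)ccnc2c1`) departs from compound 3 by methoxymethyl in place of 1-hydroxyethyl on a saturated chain carbon bound to an oxygen on an aromatic ring. The steps bearing on this change are a 1.1-fold higher number from compound 1 to compound 3 (0.06 log units; within the scatter), a 1.5-fold lower number from compound 2 to compound 3 (0.18 log units; within the scatter) and a 1.7-fold higher number from compound 1 to compound 2 (0.24 log units; within the scatter), each within the scatter. Among the compounds with values here, no measured compound carries methoxymethyl, so the evidence is indirect, and no step beyond the scatter is expected in this assay. The estimate implies an expected 1.1-fold lower number from compound 3 to compound 4 (0.03 log units; within the scatter). Compound 4 is expected at 3600 nM, with an estimated range of 1900 nM to 6800 nM.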

Compound 4, half-maximal inhibitory concentration: 6500 nM
The estimate for compound 4 lay 1.8-fold (0.26 log units) below the measured number; the range from low to high includes it.
By their numbers in this assay, from the lowest: compounds 1, 3, 2 and 4 (each within the scatter of the next).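

In this assay, 2-methoxyethyl in place of 2-hydroxypropyl gives a 1.7-fold higher number from compound 3 to compound 4 (0.22 log units; within the scatter) so removing the hydroxyl from the chain does not separate the two compounds. The same chain gives a 1.1-fold higher number from compound 2 to compound 4 (0.04 log units; within the scatter) against the free hydroxyl of compound 2. Against the chain of compound 1 it gives a 1.9-fold higher number from compound 1 to compound 4 (0.28 log units; within the scatter) so none of the four compounds separates from another at this position. As far as these compounds go, whether an amine, a carboxylic acid or a longer chain at this position would give a step beyond the scatter remains open. No supporting data bear on why these numbers fall as they do.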